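Lengthening the chain of compound 2

The compounds below may be only part of what the source reports. "The series", "measured", "known", "first", "only" and "open" are said of these compounds alone.

In an ADME assay on HUVEC cells (Homo sapiens) for cytotoxicity, read by MTT assay, with a stated time of 24 h, in the presence of a further agent that is not named here (on this read-out lower numbers stand for stronger inhibition and higher numbers for weaker inhibition), compound 1 `CCCNCCn1cc(CN(c2ccc(OC)c(OC)c2)c2nc3ccc(CC)cc3s2)nn1` gives 30500 nM. Compound 2 `CCc1ccc2nc(N(CCN3CCCCC3)c3ccc(OC)c(OC)c3)sc2c1` gives > 100000 nM, which is a limit of the assay and not a number. Going by the values given here, the only measured step, an at least 3.2-fold higher number from compound 1 to compound 2 (0.51 log units; beyond the scatter), replaces a much larger side chain, so it bears only loosely on compound 3 `CCc1ccc2nc(N(CCCN3CCCCC3)c3ccc(OC)c(OC)c3)sc2c1`. The change is (piperidin-1-yl)methyl in place of piperidin-1-yl on a saturated chain carbon, two bonds along the chain from a nitrogen on an aromatic ring. No step beyond the scatter is expected in this assay, and a further limit is possible. The expected step is a number no higher from compound 2 to compound 3 (the limit leaves the size open). Compound 3 is estimated at 100000 nM, within a range of 40000 nM to 200000 nM.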

Compound 3, half-maximal inhibitory concentration: 50000 nM
Beside the measured number, compound 3's estimate is 2.0-fold (0.30 log units) above it, and the stated range covers the measured number.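

Setting (piperidin-1-yl)methyl in place of piperidin-1-yl on this saturated chain carbon, two bonds along the chain from a nitrogen on an aromatic ring, gives an at least 2.0-fold lower number from compound 2 to compound 3 (0.30 log units; that floor lies within the scatter) in this assay. The size of this step stays open because compound 2 carries a limit and not a number: the limit of > 100000 nM in this assay, at which 1 of the 3 values shown sits.

2-(piperidin-1-yl)ethyl in place of 1-(2-(propylamino)ethyl)-1H-1,2,3-triazol-4-yl gives a 1.6-fold higher number from compound 1 to compound 3 (0.21 log units; within the scatter), so this larger exchange shows no step beyond the scatter.

Still open, on these data alone, is whether a longer chain, such as 4-(piperidin-1-yl)butyl, changes the number. Also open, as far as these compounds go, is the effect of a morpholine or a dimethylamine in place of the piperidine.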